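The source may report more compounds than this note shows. Statements on the series, on what has been measured and on what is new or still open speak of the compounds shown alone.

Working notes on the series. In a functional assay for inhibition, with Homo sapiens as the target (on this read-out lower numbers stand for stronger inhibition and higher numbers for weaker inhibition), compound 1 `CCOc1c(C(=O)Nc2nn[nH]n2)sc2ccc(OC)cc12` reads > 100000 nM, and this is a limit of the assay, not a number. In this assay, among the measured compounds shown here, compound 2 `CC(C)Oc1c(C(=O)Nc2nn[nH]n2)sc2ccc(O)cc12` gives 47800 nM, the only true number so far. For the measured compounds named here, no step between measured compounds is available, so nothing yet calibrates how far a single change moves this read-out.

Compound 3 `CC(C)Oc1c(C(=O)Nc2nn[nH]n2)sc2ccccc12` is the next to be read. It differs from compound 2 by hydrogen in place of hydroxy on an aromatic carbon, which is hydrogen in place of hydroxy on an aromatic carbon of the six-membered aromatic ring. The isopropyl ether and the rest of the shared core stay as they are.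

Going by the values given here, with no measured step to lean on, no clear direction can be argued in this assay, and the working expectation is no shift beyond the usual scatter. The expected change is a 1.1-fold lower number from compound 2 to compound 3 (0.03 log units; within the scatter), an estimate that rests only on compound 2 at 47800 nM. The estimated value for compound 3 is 45000 nM, with an expected range from 15000 nM to 100000 nM.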

Compound 3, half-maximal inhibitory concentration: > 100000 nM
Compound 3: no number, only a limit; the forecaster's own chance of this, stated with the estimate: 25%; at least 2.2-fold (0.34 log units) between middle value and limit.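

Hydrogen in place of hydroxy on an aromatic carbon supplies the first measured step in this assay, and it is beyond the usual scatter: an at least 2.0-fold higher number from compound 2 to compound 3 (0.32 log units; beyond the scatter). The position, meta to a fused ring and para to a fused ring, is therefore not silent in this read-out, since with the isopropyl ether and the rest of the shared core unchanged, only the compound carrying hydroxy there gives a true number. The step fixes a lower bound and not a size, because the read-out of compound 3 is a limit of the assay and not a number: the limit of > 100000 nM in this assay, at which 2 of the 3 values shown sit.

The compounds shown leave open whether this position calls for hydroxy itself or whether another group there, such as an amine or a carboxylic acid, would give a true number in this assay, and whether any such group would bring the number lower than that of compound 2. They also leave open how a longer chain in place of the isopropyl ether would read with hydroxy kept at this position.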